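Swapping the aryl group on a hydrazone-urea core

This account rests on a few compounds, and the source may have more. Where it says the series, first, only, none or still open, it means among the compounds named here.

Measured in a functional assay on NCI-H460 cells (Homo sapiens) for cytotoxicity, read by MTT assay, with a stated time of 72 h; on this read-out lower numbers stand for stronger inhibition and higher numbers for weaker inhibition:
Compound 1 `COc1ccc(/C=N/NC(=O)Nc2ccc(Oc3ccnc(-c4nncn4CCN(C)C)c3)c(F)c2)c(OC)c1OC` gives 1790 nM.
Compound 2 `COc1cc(/C=N/NC(=O)Nc2ccc(Oc3ccnc(-c4nncn4CCN(C)C)c3)c(F)c2)cc(OC)c1OC` gives 2770 nM.
Compound 3 `CN(C)CCn1cnnc1-c1cc(Oc2ccc(NC(=O)N/N=C/c3c(O)ccc4ccccc34)cc2F)ccn1` gives 890 nM.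

Compound 3 has the lowest number of the three, yet its step to compound 1 stays within the scatter a 2.0-fold lower number from compound 1 to compound 3 (0.30 log units; within the scatter), while its step from compound 2 is beyond it a 3.1-fold lower number from compound 2 to compound 3 (0.49 log units; beyond the scatter). Compound 4 `CN(C)CCn1cnnc1-c1cc(Oc2ccc(NC(=O)N/N=C/c3cc(Br)c(O)c(Br)c3)cc2F)ccn1` keeps the shared core and changes only the aryl group on the hydrazone carbon: 3,5-dibromo-4-hydroxyphenyl in place of 2-hydroxynaphthalen-1-yl on a carbon with a double bond to nitrogen. All three measured steps change that same group, and the largest of them is modest a 3.1-fold lower number from compound 2 to compound 3 (0.49 log units; beyond the scatter); the step of a 1.5-fold higher number from compound 1 to compound 2 (0.19 log units; within the scatter) is small. A similar, modest move in this assay is therefore expected, most likely upward from compound 3: compound 4 is estimated at 1500 nM, within 600 nM to 4000 nM, an expected step of a 1.7-fold higher number from compound 3 to compound 4 (0.23 log units; within the scatter).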

Compound 4, half-maximal inhibitory concentration: 3760 nM
Beside the measured number, compound 4's estimate is 2.5-fold (0.40 log units) below it, and the stated range covers the measured number.
By their numbers in this assay, from the lowest: compounds 3, 1, 2 and 4 (each within the scatter of the next, the first and the last beyond it).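

At this position, on a carbon with a double bond to nitrogen, 3,5-dibromo-4-hydroxyphenyl in place of 2-hydroxynaphthalen-1-yl gives the largest step yet in this assay (a 4.2-fold higher number from compound 3 to compound 4 (0.63 log units; beyond the scatter)). The same group also stands apart from 2,3,4-trimethoxyphenyl (a 2.1-fold higher number from compound 1 to compound 4 (0.32 log units; beyond the scatter)), but not from 3,5-trimethoxy's close relative 3,4,5-trimethoxyphenyl (a 1.4-fold higher number from compound 2 to compound 4 (0.13 log units; within the scatter)). No supporting measurement explains these steps. From the compounds shown here alone, how an amine or a carboxylic acid on this carbon would behave remains open.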